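A few compounds are considered here, and "the series" means these few. Any claim that something is new, unique, unknown or untested is made for them only; others in the source may bear on it.

The study sets three measured compounds beside one still to be tested in a functional assay for inhibition, with Homo sapiens as the target; on this read-out lower numbers stand for stronger inhibition and higher numbers for weaker inhibition. Compound 2 `C=CCn1ncc2c(C)nc(CCC)n2c1=O` gives 40000 nM in this assay. Compound 1 `C=CCn1ncc2c(C)nc(CC)n2c1=O` carries a shorter chain on the same core; its result in this assay, > 48000 nM, is a limit of the measurement and not a number. The change from compound 2 to compound 1 is hydrogen in place of methyl on a saturated chain carbon, two bonds along the chain from an aromatic carbon, and the step is an at least 1.2-fold higher number from compound 2 to compound 1 (0.07 log units; that floor lies within the scatter), which rests on (the limit of > 48000 nM in this assay, at which 2 of the 3 values shown sit). Compound 3 `CCCc1nc(C)c2c(CC)cnc(Nc3cc[nH]n3)n12` is built on a different core, and how the core of compound 3 differs from that of compound 2 is not broken down here. In this assay compound 3 gives > 48000 nM, again a limit and not a number. Compound 4 `CCCc1nc(C)c2c(C)cnc(Nc3cc[nH]n3)n12` is yet to be measured in this assay. It differs from compound 3 by hydrogen in place of methyl on a saturated chain carbon bound to an aromatic carbon. Going by the values given here, this is the same kind of change as the one from compound 2 to compound 1, but not the same: there the hydrogen enters on a saturated chain carbon two bonds along the chain from an aromatic carbon, here on a saturated chain carbon bound to an aromatic carbon. With compound 3 already at the limit of > 48000 nM in this assay, compound 4 is expected to show a step that the limit leaves unreadable from compound 3 to compound 4. Compound 4 is therefore estimated at 70000 nM in this assay, between 30000 nM and 200000 nM.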

Compound 4, half-maximal inhibitory concentration: > 48000 nM
Compound 4: only a limit was reported; the forecaster's own chance of this, stated with the estimate: 75%; the middle value lies beyond the limit too.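

In this assay compound 4 gives > 48000 nM as a limit of the measurement and not a number. No step can be read from compound 3 to compound 4, because both compounds stand at a limit: the limit of > 48000 nM in this assay, at which 3 of the 4 values shown sit. The compounds shown leave open how strongly compound 3 and compound 4 inhibit, and whether hydrogen in place of methyl at this place changes inhibition at all.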